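The compounds below may be only part of what the source reports. "The series", "measured", "known", "first", "only" and "open" are said of these compounds alone.

Measured so far in a functional assay on HEK293 cells for agonist activity at Bile acid receptor (Homo sapiens); on this read-out higher numbers stand for larger maximal responses and lower numbers for smaller maximal responses:
Compound 1, `Cc1cc(C(F)(F)F)cc(OCc2c(-c3c(Cl)cccc3Cl)noc2C(C)C)n1`, gives "not active" (no number reported).
Compound 2, `CC(C)c1onc(-c2c(Cl)cccc2Cl)c1COc1cnc(N(C)Cc2ccc(C(=O)O)cc2)c(Cl)c1`, gives 70%.
Compound 3, `CC(Nc1ccc(C(=O)O)cc1)c1ccc(OCc2c(-c3c(Cl)cccc3Cl)noc2C2CC2)nc1C(F)(F)F`, gives 59%.

On these numbers compound 3 stands lowest of the two reported values; the nearest is compound 2, whose value lies higher by a margin beyond the usual scatter, and compound 1 returned no single number. Compound 4, `CC(Oc1cccc(C(=O)O)c1)c1ccc(OCc2c(-c3c(Cl)cccc3Cl)noc2C2CC2)nc1C(F)(F)F`, is the next entry to be measured in this assay. It differs from compound 3 in one place: 3-carboxyphenoxy in place of (4-carboxyphenyl)amino on a saturated chain carbon bound to an aromatic carbon and a saturated chain carbon. Going by the values given here, no step between two measured compounds that differ in one place is available, so the size of this change has no direct precedent. Among the compounds with values here, with only two numbers and one entry without a number to go on, a moderate step downward is expected rather than none, and compound 4 is estimated at 48%, within a range from 20% to 72%. The step expected from this change is a number 11 percentage points lower from compound 3 to compound 4 (beyond the scatter).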

Compound 4, largest response reached (reported as efficacy), in percent of the reference or control that the assay uses: 50%
For compound 4 the middle estimate is 2 percentage points below the measured one; the range from low to high includes it.
By their numbers in this assay, from the lowest: compounds 4 and 3 (each within the scatter of the next); then compound 2.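

In this assay, going by these compounds alone, the exchange of (4-carboxyphenyl)amino for 3-carboxyphenoxy on the saturated chain carbon gives a number 9 percentage points lower from compound 3 to compound 4 (within the scatter) and is the first one-place comparison. At this place the read-out therefore does not separate the two groups, even though the exchange replaces the amino nitrogen with oxygen, leaves one hydrogen-bond donor fewer and alters the numbering of the carboxy group in a single step. No supporting measurement bears on this result.

Because both features change together, the contribution of the linking atom and that of the carboxy numbering remain unresolved, and 4-carboxyphenoxy would separate them. Also open, from the compounds shown here alone, is how this place responds to a sulfur link, or to a primary amide or tetrazole in place of the carboxylic acid.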